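Methyl in place of fluoro-methoxy on the enone aryl ring

The source may hold more compounds than are shown below. What is called first, only, known or untested is meant among the compounds shown, and "the series" means these compounds.

Measured compounds in a functional assay on SW-620 cells (Homo sapiens) for cytotoxicity, read by MTT assay, with stated times of 4 h and 72 h, tested at 2 uM; on this read-out lower numbers stand for stronger inhibition and higher numbers for weaker inhibition:
compound 1 `COc1ccc(/C=C/C(=O)c2ccc(Nc3cc(C)nc4nc(SCc5nc6ccccc6[nH]5)nn34)cc2)cc1` gives 170 nM
compound 2 `Cc1cc(Nc2ccc(C(=O)/C=C/c3ccc(Cl)cc3)cc2)n2nc(SCc3nc4ccccc4[nH]3)nc2n1` gives 230 nM
compound 3 `COc1ccc(/C=C/C(=O)c2ccc(Nc3cc(C)nc4nc(SCc5nc6ccccc6[nH]5)nn34)cc2)cc1F` gives 140 nM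

Compound 3 shows the lowest of the three numbers in this assay, but its gap to compound 1 and to compound 2 both sit within the scatter, so the three compounds cannot be ranked against one another. Compound 4 `Cc1ccc(/C=C/C(=O)c2ccc(Nc3cc(C)nc4nc(SCc5nc6ccccc6[nH]5)nn34)cc2)cc1` has not yet been measured. It differs from compound 3 in one place: 4-methylphenyl in place of 3-fluoro-4-methoxyphenyl on a double-bonded chain carbon bound to a double-bonded chain carbon

Two of the measured steps bear on this change, since both alter the same aryl ring on the double-bonded chain. The step of a 1.4-fold higher number from compound 1 to compound 2 (0.13 log units; within the scatter) and the step of a 1.6-fold lower number from compound 2 to compound 3 (0.22 log units; within the scatter) are each within the scatter, so swapping substituents on that ring has so far moved the number very little. A methyl group on that ring has not been seen, yet nothing in these steps points to a move beyond the scatter in either direction.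

Compound 4 is therefore expected to give 190 nM in this assay, with a range from 95 nM to 380 nM. That estimate corresponds to a step of a 1.4-fold higher number from compound 3 to compound 4 (0.13 log units; within the scatter), which is expected to remain within the scatter.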

Compound 4, half-maximal inhibitory concentration: 1520 nM
Compound 4: middle estimate off by 8.0-fold (0.90 log units), on the low side; measured number above the stated range.
By their numbers in this assay, from the lowest: compounds 3, 1 and 2 (each within the scatter of the next); then compound 4.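

In this assay, among the compounds shown here, the aryl ring on the double-bonded chain proves less tolerant than the earlier compounds suggested: 4-methylphenyl is the first group there to move the number beyond the scatter, with an 11-fold higher number from compound 3 to compound 4 (1.04 log units; beyond the scatter) and with an 8.9-fold higher number from compound 1 to compound 4 (0.95 log units; beyond the scatter) as well as a 6.6-fold higher number from compound 2 to compound 4 (0.82 log units; beyond the scatter). The loss of the fluoro group cannot by itself account for this, since compound 1 and compound 2 carry no fluoro group and remain within the scatter of compound 3, so the shift appears when methyl takes the place of methoxy or chloro on that aromatic carbon. Nothing available here explains why methyl parts so sharply from methoxy and chloro on this ring.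

The compounds shown leave open whether an ethyl, a trifluoromethyl or a dimethylamino group on that aromatic carbon would follow methyl or would instead stay with methoxy and chloro. They also leave open whether adding a fluoro group to the 4-methylphenyl ring would bring the number back towards those of the other three compounds.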